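Dropping One Chloro from an Allyl-Bearing Dopamine Receptor Ligand

The source may report more compounds than this note shows. Statements on the series, on what has been measured and on what is new or still open speak of the compounds shown alone.

Of the compounds shown here, three sharing one core have been measured in an assay on isolated protein for displacement of a labelled ligand from D(1B) dopamine receptor (Homo sapiens); a higher number here means a weaker inhibitor, a lower number a stronger inhibitor. Compound 1 `COc1cc2c(cc1O)C(c1c(Cl)cccc1Cl)CNCC2` gives 25.4 nM. Compound 2 `C=CCN1CCc2cc(OC)c(O)cc2C(c2ccccc2Br)C1` gives 501 nM, and compound 3 `C=CCN1CCc2cc(OC)c(O)cc2C(c2c(Cl)cccc2Cl)C1` gives 479 nM. Among these three numbers compound 3 stands second highest; its nearest neighbour is compound 2, and the gap a 1.0-fold lower number from compound 2 to compound 3 (0.02 log units; within the scatter) lies within the scatter, while the far more distant compound 1 is separated by the step of a 19-fold higher number from compound 1 to compound 3 (1.28 log units; beyond the scatter), which came with allyl in place of hydrogen on an amine nitrogen in a ring.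

Compound 4 `C=CCN1CCc2cc(OC)c(O)cc2C(c2ccccc2Cl)C1` has not yet been measured. It differs from compound 3 in one place: hydrogen in place of chloro on an aromatic carbon; read one bond further out, the change is 2,6-dichlorophenyl to 2-chlorophenyl. The measured step that bears on this is a 1.0-fold lower number from compound 2 to compound 3 (0.02 log units; within the scatter), where 2,6-dichlorophenyl took the place of 2-bromophenyl on a saturated ring carbon without any shift beyond the scatter. Removing one chloro from that ring is therefore expected to matter little in this assay, and the expected step is a 1.0-fold higher number from compound 3 to compound 4 (0.02 log units; within the scatter). Compound 4 is estimated at 500 nM, with a range from 200 nM to 1300 nM.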

Compound 4, inhibition constant: 264 nM
For compound 4 the middle estimate is 1.9-fold (0.28 log units) above the measured one; low and high end bracket the measured number.
By their numbers in this assay, from the lowest: compound 1; then compounds 4, 3 and 2 (each within the scatter of the next).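

In this assay, the step of a 1.8-fold lower number from compound 3 to compound 4 (0.26 log units; within the scatter) shows that the allyl compounds keep their standing when this chloro gives way to hydrogen, so a second chloro on the ring is not needed to stay in this range. The halogen that remains can also be exchanged, since the step of a 1.9-fold lower number from compound 2 to compound 4 (0.28 log units; within the scatter) is no larger than the scatter either, and the 2-bromophenyl, 2,6-dichlorophenyl and 2-chlorophenyl groups cannot be told apart here. Taken together, the position accepts all three substitution patterns on the ring while the allyl group stays on the nitrogen, though no measurement at hand offers an explanation for this.

Still open, on these data alone, is whether this tolerance lasts once the last halogen goes, as in a plain phenyl ring, or when a different group such as methoxy or nitrile takes the place of the remaining chloro. As far as these compounds go, it is equally open whether a 2-chlorophenyl group would be tolerated as well on the core of compound 1, with hydrogen rather than allyl on the ring nitrogen.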